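Methyl on the benzo ring of compound 1

The compounds below may be only part of what the source reports. "The series", "measured", "known", "first", "only" and "open" are said of these compounds alone.

Compound 1 `CC(C)(O)c1cncc(-n2ncc3ccccc32)c1` gives the higher of the two numbers in an assay on cells for inhibition of cytochrome P450 11B2, mitochondrial (Homo sapiens), read by HTRF, with stated times of 1 h and 3 h (on this read-out higher numbers stand for weaker inhibition and lower numbers for stronger inhibition), at 15 nM; compound 2 `CC(C)(O)c1cncc(-n2ncc3cccc(F)c32)c1` gives 0.9 nM, and the step of a 17-fold lower number from compound 1 to compound 2 (1.22 log units; beyond the scatter) came with a fluoro in place of hydrogen on an aromatic carbon. Compound 3 `Cc1ccc2c(cnn2-c2cncc(C(C)(C)O)c2)c1` carries instead (methyl in place of hydrogen on an aromatic carbon), at a different place on the same ring. Within the data shown here, no measured step tests that place directly, so the fluoro step is only a loose guide, and a smaller gain is expected in this assay. Compound 3 is thus estimated at 8 nM, with a range of 2 nM to 40 nM, meaning an expected step of a 1.9-fold lower number from compound 1 to compound 3 (0.27 log units; within the scatter).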

Compound 3, half-maximal inhibitory concentration: 97.9 nM
Compound 3: the middle estimate sits 12-fold (1.09 log units) below what was measured; measured number outside the range, above it.
By their numbers in this assay, from the lowest: compound 2; then compound 1; then compound 3.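

At this place on the six-membered aromatic ring of carbon only, methyl in place of hydrogen goes with a 6.5-fold higher number from compound 1 to compound 3 (0.81 log units; beyond the scatter) in this assay, a loss of inhibition. A single small substituent on this ring can therefore move the number either way: the fluoro step, at another place, gave a 17-fold lower number from compound 1 to compound 2 (1.22 log units; beyond the scatter). Nothing shown gives a reason for the loss. Going by these compounds, whether it follows the place or the group stays open, as the two steps differ in both. A chloro or a methoxy group at this place would bear on that question.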